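The source may hold more compounds than are shown below. What is called first, only, known or untested is meant among the compounds shown, and "the series" means these compounds.

Within the data shown here, in an ADME assay on MRC5 cells (Homo sapiens), read by MTT assay, with a stated time of 72 h (a lower number here means a stronger inhibitor, a higher number a weaker inhibitor), compound 2 `COc1ncnc2c1c(I)cn2[C@@H]1O[C@H](CO)[C@@H](O)[C@H]1O` gives 63000 nM, the only plain number among the values in hand. Compound 1 `Nc1nc(N)c2c(-c3ccsc3)cn([C@@H]3O[C@H](CO)[C@@H](O)[C@H]3O)c2n1` returns only a limit of the assay, > 100000 nM. That limit is recorded as the limit of > 100000 nM in this assay, at which 1 of the 2 values shown sits, and so no comparison of size between the two measured compounds can be drawn from it. Compound 3 `COc1ncnc2c1c(-c1cccs1)cn2[C@@H]1O[C@H](CO)[C@@H](O)[C@H]1O` is still to be tested in this assay. It differs from compound 2 in a single place: thiophen-2-yl in place of iodo on an aromatic carbon. Among the measured compounds shown here, with no measured step between two compounds available, the effect of this change is a matter of expectation only. The step from compound 2 to compound 3 in this assay is expected to be a modest weakening, a 1.4-fold higher number from compound 2 to compound 3 (0.15 log units; within the scatter), which may not exceed the usual scatter. Compound 3 is therefore estimated at 90000 nM, with a likely range from 30000 nM to 250000 nM, and a real chance that only a limit is reported.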

Compound 3, half-maximal inhibitory concentration: 43200 nM
Compound 3: the middle estimate sits 2.1-fold (0.32 log units) above what was measured; low and high end bracket the measured number.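

In this assay, among these compounds, replacing iodo with thiophen-2-yl gives the one readable step at this position, on an aromatic carbon two ring bonds from the ring nitrogen: a 1.5-fold lower number from compound 2 to compound 3 (0.16 log units; within the scatter). A group of 5 heavy atoms with one five-membered aromatic ring thus enters in place of a single iodine atom, and the difference between the two compounds stays within the scatter. This finding rests on one pair alone, and it shows that this particular change on the shared core leaves no difference that can be told apart in this read-out.

Going by these compounds, whether an amine or a carboxylic acid on this carbon would move the number beyond the scatter remains open. Compound 1 offers no further step, since it gives only a limit of the assay: the limit of > 100000 nM in this assay, at which 1 of the 3 values shown sits.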